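The compounds below may be only part of what the source reports. "The series", "measured", "known", "first", "only" and "open" are said of these compounds alone.

Measured in a functional assay on the whole organism with Rattus norvegicus as the target; a lower number here means that less compound is needed, a higher number that more compound is needed for the effect:
- compound 1 `CCOc1ccccc1-c1ncc(-c2nn[nH]n2)c(O)n1`: 0.09 mg/kg
- compound 2 `CCC(C)Oc1ccccc1-c1ncc(-c2nn[nH]n2)c(O)n1`: 0.05 mg/kg

Only these two compounds have been measured in this assay, and compound 2, at 0.05 mg/kg, lies within the scatter of compound 1. The next compound, compound 3 `CCCCCOc1ccccc1-c1ncc(-c2nn[nH]n2)c(O)n1`, has pentyl in place of sec-butyl on an oxygen on an aromatic ring. Going by the values given here, one measured step bears on this change, as it also alters the chain on that oxygen: a 1.8-fold lower number from compound 1 to compound 2 (0.26 log units; within the scatter). That step lies within the scatter, so the chain has so far shown no clear effect on the number, though a single step is thin evidence. No change beyond the scatter is therefore expected, and the estimated step is a 1.6-fold higher number from compound 2 to compound 3 (0.20 log units; within the scatter). For compound 3 the expected value is 0.08 mg/kg, with an estimated range from 0.03 mg/kg to 0.25 mg/kg.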

Compound 3, dose for 50% inhibition: 0.4 mg/kg
Compound 3: the middle estimate sits 5.0-fold (0.70 log units) below what was measured; measured number outside the range, above it.
By their numbers in this assay, from the lowest: compounds 2 and 1 (each within the scatter of the next); then compound 3.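

At the chain on the oxygen on an aromatic ring, the number in this assay proved responsive after all: pentyl in place of sec-butyl gives an 8.0-fold higher number from compound 2 to compound 3 (0.90 log units; beyond the scatter), and the comparison with the ethyl chain of compound 1 gives a 4.4-fold higher number from compound 1 to compound 3 (0.65 log units; beyond the scatter). The position that had shown no clear effect between ethyl and sec-butyl therefore does not tolerate every alkyl chain equally, and with pentyl more compound is needed for the effect. Nothing available here accounts for this difference.

The compounds shown leave open whether the rise depends on the extra carbon, on the unbranched form of the chain, or on both, and an unbranched butyl or a branched pentyl chain would help separate these. Also open, going by these compounds, is how a chain ending in an amine or a carboxylic acid would behave at this position.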